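The compounds below may be only part of what the source reports. "The series", "measured", "known", "first", "only" and "open" are said of these compounds alone.

Working notes on the series. All four compounds share the same core, shown in compound 1 `N[C@H]1CC[C@H](Nc2c(C(=O)NCc3ccc(Cl)cc3)nc(Br)c3cccnc23)CC1`, and differ only in the ring attached through the amide-linked methylene. In a functional assay on SK-BR-3 cells (Homo sapiens) for cytotoxicity, read by MTT assay, with a stated time of 72 h (on this read-out lower numbers stand for stronger inhibition and higher numbers for weaker inhibition), compound 1 gives 2000 nM. Compound 2 `N[C@H]1CC[C@H](Nc2c(C(=O)NCc3ccccn3)nc(Br)c3cccnc23)CC1` carries a pyridine-bearing amide; in this assay compound 2 stands at "not determined" (no result reported), so no number is available for it. Compound 3 `N[C@H]1CC[C@H](Nc2c(C(=O)NCc3cccs3)nc(Br)c3cccnc23)CC1` carries the (thiophen-2-yl)methyl amide; in this assay compound 3 likewise stands at "not determined" (no result reported). For the measured compounds named here, compound 3 therefore has no number of its own, and no step between it and any measured compound can be read; the only anchor for the series in this assay is compound 1.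

Compound 4 `COc1ccc(CNC(=O)c2nc(Br)c3cccnc3c2N[C@H]2CC[C@H](N)CC2)cc1` differs from compound 3 by 4-methoxyphenyl in place of thiophen-2-yl on a saturated chain carbon bound to an amide-type nitrogen. With no result for compound 3, the step from compound 3 to compound 4 in this assay cannot be sized from data. The exchange of one outer aromatic ring for another at the same position gives no ground to expect a step beyond the scatter in either direction, so the working expectation is a value in the region where compound 1 stands at 2000 nM, with a wide range to reflect the missing anchor.

Compound 4 is expected to give 2500 nM in this assay, with a range from 700 nM to 9000 nM.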

Compound 4, half-maximal inhibitory concentration: 5000 nM
Compound 4: the middle estimate sits 2.0-fold (0.30 log units) below what was measured; the range from low to high includes it.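

In this assay, the series now has its first readable step at the outer ring: methoxy in place of chloro on an aromatic carbon gives a 2.5-fold higher number from compound 1 to compound 4 (0.40 log units; beyond the scatter), which shows that this single exchange moves the read-out beyond the usual scatter, towards weaker inhibition. The two measured compounds thus show that this position is not indifferent to the group on the aromatic carbon, although two groups set no trend, and the steps involving compound 2 or compound 3, including the exchange of thiophen-2-yl for 4-methoxyphenyl, cannot be read. No measurement at hand speaks to what lies behind this step.

As far as these compounds go, it remains open how a plain benzyl, or a hydroxyl, fluoro or dimethylamino group on the same aromatic carbon, would read in this assay, and so whether chloro and methoxy mark two points on a wider spread or sit close to its limits. Also open, from the compounds shown here alone, is whether a longer chain in place of the single saturated carbon bound to the amide-type nitrogen would keep, enlarge or reverse the step seen here.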